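Ethynyl for Methyl on a Second Fused Core

The source may report more compounds than this note shows. Statements on the series, on what has been measured and on what is new or still open speak of the compounds shown alone.

Compound 1 `Cc1ccn2cc(-c3ccc(NC(=O)Nc4cc(C(C)(C)C)on4)cc3)nc2c1` and compound 2 `C#Cc1ccn2cc(-c3ccc(NC(=O)Nc4cc(C(C)(C)C)on4)cc3)nc2c1` share a core; in a functional assay on MV4-11 cells (Homo sapiens) for cytotoxicity, read by MTT assay, with a stated time of 72 h (on this read-out lower numbers stand for stronger inhibition and higher numbers for weaker inhibition), compound 1 gives 0.79 nM and compound 2 gives 3.46 nM. The change between them is ethynyl in place of methyl on an aromatic carbon, and it gave a 4.4-fold higher number from compound 1 to compound 2 (0.64 log units; beyond the scatter). Compound 3 `Cc1ccc2nc(-c3ccc(NC(=O)Nc4cc(C(C)(C)C)on4)cc3)cn2c1` carries the same atoms on a differently joined core; the difference between the two cores is not broken down here. In this assay compound 3 gives 4.08 nM. Compound 4 `C#Cc1ccc2nc(-c3ccc(NC(=O)Nc4cc(C(C)(C)C)on4)cc3)cn2c1` differs from compound 3 by ethynyl in place of methyl on an aromatic carbon, the same kind of change as before, though here the place lies two atoms from the ring nitrogen rather than opposite the ring nitrogen. Because compound 1 to compound 2 showed a 4.4-fold higher number from compound 1 to compound 2 (0.64 log units; beyond the scatter), a comparable step is expected here: a 3.7-fold higher number from compound 3 to compound 4 (0.57 log units; beyond the scatter). Compound 4 is therefore estimated at 15 nM, with a range from 5 nM to 45 nM.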

Compound 4, half-maximal inhibitory concentration: 8.62 nM
Compound 4: middle estimate off by 1.7-fold (0.24 log units), on the high side, within the range that was stated.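

In this assay, ethynyl in place of methyl gave a 2.1-fold higher number from compound 3 to compound 4 (0.32 log units; beyond the scatter), so the number rose on this core as it did on the core of compound 1. The two steps cannot be told apart in size: the same change on two cores in this assay, a 4.4-fold higher number (0.64 log units; beyond the scatter) from compound 1 to compound 2 and a 2.1-fold higher number (0.32 log units; beyond the scatter) from compound 3 to compound 4, 2.1-fold (0.32 log units) apart, within the scatter of two such steps. The change therefore carried over between these two cores in direction and, within the scatter, in size, but two pairs cannot show that it would do so on any further core, nor do they explain why the number rises.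

Still open, as far as these compounds go, is how other groups at these places would compare with methyl and ethynyl, such as a nitrile, an amine or a longer chain like propyl.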